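The compounds below may be only part of what the source reports. "The series", "measured", "known", "first", "only" and "open" are said of these compounds alone.

In a functional assay (muscle tissue) with Cavia porcellus as the target (on this read-out higher numbers stand for an effect only at larger amounts of compound and lower numbers for an effect already at smaller amounts), three compounds built on one shared core have been measured. Compound 1 `COC(=O)C1=C(C)N=C(C)/C(=C(\O)OC)C1c1ccccc1OC` gives 57.5 nM and compound 2 `COC(=O)C1=C(C)N=C(C)/C(=C(\O)OC)C1c1ccccc1C(F)(F)F` gives 1.51 nM. Compound 3 `COC(=O)C1=C(C)N=C(C)/C(=C(\O)OC)C1c1ccc(I)cc1` gives 22900 nM, the highest number of the three and well beyond the scatter of the other two.

The unmeasured compound 4 `COC(=O)C1=C(C)N=C(C)/C(=C(\O)OC)C1c1ccccc1F` differs from compound 3 in one place: 2-fluorophenyl in place of 4-iodophenyl on a saturated ring carbon. Going by the values given here, two measured steps bear on this change. Bringing in the 4-iodophenyl group gave a 400-fold higher number from compound 1 to compound 3 (2.60 log units; beyond the scatter), a large rise, so taking that group away may undo much of it. The second step, a 38-fold lower number from compound 1 to compound 2 (1.58 log units; beyond the scatter), is also large and shows that trifluoromethyl in place of methoxy alone can shift the number strongly. Among the compounds with values here, no measured compound carries fluorine, so the data cannot place the new group exactly. Compound 4 is therefore expected to land within or near the span of compound 1 and compound 2.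

The expected change is a large drop, a 1100-fold lower number from compound 3 to compound 4 (3.06 log units; beyond the scatter). For compound 4 the estimate is 20 nM, with an expected range from 4 nM to 100 nM.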

Compound 4, half-maximal effective concentration: 42.7 nM
Beside the measured number, compound 4's estimate is 2.1-fold (0.33 log units) below it; measured number inside the range.
By their numbers in this assay, from the lowest: compound 2; then compounds 4 and 1 (each within the scatter of the next); then compound 3.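

In this assay, 2-fluorophenyl in place of 4-iodophenyl gives a 540-fold lower number from compound 3 to compound 4 (2.73 log units; beyond the scatter) and shows that this saturated ring carbon is highly sensitive to which aryl group it carries. On the aromatic carbon, fluoro in place of methoxy gives a 1.3-fold lower number from compound 1 to compound 4 (0.13 log units; within the scatter) and so cannot be told apart from methoxy here, whereas fluoro in place of trifluoromethyl gives a 28-fold higher number from compound 2 to compound 4 (1.45 log units; beyond the scatter) and sets trifluoromethyl apart from both. No measured evidence is available to explain these shifts.

On these data alone, the change from 4-iodophenyl to 2-fluorophenyl alters both the halogen and its place on the phenyl ring, so the share of each in the large step stays open. A 4-fluorophenyl group would separate those two changes, and a 2-nitrophenyl or 2-chlorophenyl group would show how far the trifluoromethyl result extends to other groups.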